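Methyl extension on the core of compound 2: expected cytotoxicity

A few compounds are considered here, and "the series" means these few. Any claim that something is new, unique, unknown or untested is made for them only; others in the source may bear on it.

Compound 1 `COC(=O)c1c(C)[n+]([O-])c2ccc(OC)cc2[n+]1[O-]`, 52.6 ug/mL
Compound 2 `COC(=O)c1c(C)[n+]([O-])c2ccccc2[n+]1[O-]`, > 10 ug/mL
Compound 3 `COC(=O)c1c(C)[n+]([O-])c2cc(F)c(F)cc2[n+]1[O-]`, 1.48 ug/mL

Of the compounds shown here, three sharing one core have been measured in an ADME assay on Vero cells (Chlorocebus sabaeus) for cytotoxicity; on this read-out higher numbers stand for weaker inhibition and lower numbers for stronger inhibition. Compound 1 gives 52.6 ug/mL and compound 3 gives 1.48 ug/mL. For compound 2 this assay reports only a limit, > 10 ug/mL, so compound 2 stands on a threshold rather than on a number. Among the compounds with values here, the one measured step that touches compound 2, a step that the limit leaves unreadable from compound 1 to compound 2, cannot be read in size, as the limit of > 10 ug/mL in this assay, at which 1 of the 3 values shown sits, hides it.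

Compound 4 `CCc1c(C(=O)OC)[n+]([O-])c2ccccc2[n+]1[O-]` has not been measured. Its change from compound 2 is methyl in place of hydrogen on a saturated chain carbon bound to an aromatic carbon, which read one bond further out is methyl to ethyl. Within the data shown here, no measured step alters a saturated chain carbon, and the only step into compound 2 is unreadable, so nothing measured bears directly on this change. With no evidence of movement, the expected step that the limit leaves unreadable from compound 2 to compound 4 is estimated to stay within the scatter. Compound 4 is therefore expected to give 15 ug/mL, with a range from 5 ug/mL to 45 ug/mL in this assay.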

Compound 4, half-maximal inhibitory concentration: 47 ug/mL
Compound 4: middle estimate off by 3.1-fold (0.50 log units), on the low side; the measured number lies above the stated range.
By their numbers in this assay, from the lowest: compound 3; then compounds 4 and 1 (each within the scatter of the next).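

No new step can be read in this assay, since compound 2 carries only a limit and the change from compound 2 to compound 4 therefore has no readable size: the limit of > 10 ug/mL in this assay, at which 1 of the 4 values shown sits. The compounds shown leave open how far methyl in place of hydrogen on a saturated chain carbon bound to an aromatic carbon shifts the value in this assay.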